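From hydroxy to methoxy: compound 2 becomes compound 3

A few compounds are considered here, and "the series" means these few. Any claim that something is new, unique, unknown or untested is made for them only; others in the source may bear on it.

In an ADME assay on Vero cells (Chlorocebus sabaeus) for cytotoxicity, read by MTT assay, with a stated time of 72 h (on this read-out lower numbers stand for higher toxicity in this test and higher numbers for lower toxicity in this test), compound 1 `CCOC(=O)CN1CCN(c2c(F)cc3c(=O)c(C(=O)O)cn(C4CC4)c3c2OC)CC1C` gives 1000 ug/mL and compound 2 `COc1c(N2CCN(CC/C(C)=N/O)C(C)C2)c(F)cc2c(=O)c(C(=O)O)cn(C3CC3)c12` gives 44.2 ug/mL, so compound 2 holds the lower of the two numbers. Compound 3 `CO/N=C(\C)CCN1CCN(c2c(F)cc3c(=O)c(C(=O)O)cn(C4CC4)c3c2OC)CC1C` has not yet been measured. It differs from compound 2 by one change: methyl in place of hydrogen on an oxygen, which is methyl in place of hydrogen on an oxygen, or hydroxy to methoxy.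

Within the data shown here, only one measured step bears on this, and only loosely: a 23-fold lower number from compound 1 to compound 2 (1.35 log units; beyond the scatter). That large step exchanged a whole group on a saturated chain carbon bound to an amine nitrogen in a ring, far more than the present change. Among the measured compounds shown here, no measured pair shows what this methyl does alone. The chain of compound 1 carries no hydroxy and its value is 1000 ug/mL, which is a weak hint towards a higher number. A much smaller move is therefore expected in this assay, with the estimated 1.4-fold higher number from compound 2 to compound 3 (0.13 log units; within the scatter) staying within the scatter. The expected value for compound 3 is 60 ug/mL, with an estimated range from 22 ug/mL to 200 ug/mL.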

Compound 3, half-maximal cytotoxic concentration: 157 ug/mL
Estimate against measurement, compound 3: 2.6-fold (0.42 log units) below, within the range that was stated.
By their numbers in this assay, from the lowest: compound 2; then compound 3; then compound 1.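

In this assay, methyl in place of hydrogen on an oxygen gives a 3.6-fold higher number from compound 2 to compound 3 (0.55 log units; beyond the scatter), so even this one added carbon, on an oxygen whose other neighbour is a double-bonded nitrogen, moves the number beyond the usual scatter and towards lower toxicity in this test. The methoxy chain still does not match the chain with the ethyl ester, with a 6.4-fold lower number from compound 1 to compound 3 (0.80 log units; beyond the scatter), which means that this small change closes only part of the larger gap seen in a 23-fold lower number from compound 1 to compound 2 (1.35 log units; beyond the scatter) and that the chain as a whole still matters for this read-out. The information available offers no measured explanation for why this methyl shifts the number.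

As far as these compounds go, what remains open is whether the number keeps rising as the group on this oxygen grows, for example with an ethyl group, a longer chain or a chain ending in a carboxylic acid, or whether the rise stops at methyl. From the compounds shown here alone, it is also open whether hydroxy to methoxy would give a step of similar size on a chain of a different length or on another core.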